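The compounds below may be only part of what the source reports. "The series", "measured", "known", "first", "only" and "open" are said of these compounds alone.

Working notes on the series.

Two compounds have numbers in a functional assay on MDA-MB-435 cells (Homo sapiens) for antiproliferative activity, read by sulforhodamine B assay, with a stated time of 48 h; on this read-out lower numbers stand for stronger inhibition and higher numbers for weaker inhibition. Compound 1 `COc1cc(-c2nn(-c3ccc(NC(=O)c4ccc(Cl)c(Cl)c4)cc3)cc2-c2ccncc2)ccc1Cl` gives 7130 nM in this assay. Compound 2 `O=C(Nc1ccc(-n2cc(-c3ccncc3)c(-c3ccc(Cl)c(O)c3)n2)cc1)Nc1ccc(Cl)c(C(F)(F)F)c1` gives 1320 nM in this assay, the lowest of the two numbers; the nearest is compound 1, whose number is higher by a margin beyond the scatter.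

Compound 3 `O=C(Nc1ccc(-n2cc(-c3ccncc3)c(-c3ccc(Cl)c(O)c3)n2)cc1)c1ccc(Cl)c(Cl)c1` is not yet measured. Relative to compound 2 the change is 3,4-dichlorophenyl in place of (4-chloro-3-(trifluoromethyl)phenyl)amino on a carbonyl carbon. Going by the values given here, no pair of measured compounds differs in this one place alone, so the size of the step can only be guessed. Compound 1 carries the same 3,4-dichlorophenyl on the carbonyl carbon but differs from compound 3 elsewhere, and compound 1 gives 7130 nM in this assay, a higher number than compound 2. Taken with caution, this hints that the step from compound 2 to compound 3 may move toward a higher number, of modest size, and it could also stay within the scatter. Compound 3 is expected at 3000 nM, between 1000 nM and 9000 nM, which means an estimated step of a 2.3-fold higher number from compound 2 to compound 3 (0.36 log units; beyond the scatter).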

Compound 3, half-maximal inhibitory concentration: 2730 nM
Beside the measured number, compound 3's estimate is 1.1-fold (0.04 log units) above it; measured number inside the range.
By their numbers in this assay, from the lowest: compound 2; then compound 3; then compound 1.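

In this assay the carbonyl carbon with its amide-type nitrogen is now shown to be a place that responds: 3,4-dichlorophenyl in place of (4-chloro-3-(trifluoromethyl)phenyl)amino gives a 2.1-fold higher number from compound 2 to compound 3 (0.32 log units; beyond the scatter) as a modest change, and the group that enters has no hydrogen-bond donor while the group that leaves has one. Compound 3 also links the series at a second place, since hydrogen in place of methyl on an oxygen on an aromatic ring gives a 2.6-fold lower number from compound 1 to compound 3 (0.42 log units; beyond the scatter) and is likewise modest, whereas compound 1 and compound 2 differ at both places and could not separate them. Nothing measured on these compounds accounts for either step.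

The first step swaps the amino link and the ring substituents together, so the share of each remains unresolved, and a plain phenyl or a 3-trifluoromethyl-4-chlorophenyl directly on the carbonyl carbon would bear on that. At the oxygen, only hydrogen and methyl are shown, which leaves open how a longer chain such as ethyl, or an amine-bearing chain, would read in this assay on the core of compound 3.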